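Aminophenylsulfonyl fluorouracil series, antiproliferative notes

The source may hold more compounds than are shown below. What is called first, only, known or untested is meant among the compounds shown, and "the series" means these compounds.

Measured so far:
- compound 1, `Nc1ccc(S(=O)(=O)N2CC(n3cc(F)c(=O)[nH]c3=O)OCc3ccccc32)cc1`: 14400 nM
- compound 2, `Clc1ncnc2ncn(C3CSc4ccccc4CO3)c12`: 1250 nM

In a functional assay on MCF7 cells (Homo sapiens) for antiproliferative activity (a lower number here means a stronger inhibitor, a higher number a weaker inhibitor), compound 1 gives 14400 nM, the higher of the two numbers recorded. Going by the values given here, compound 2, built on a different core, gives 1250 nM; the gap between the two lies beyond the scatter, and no single-point step connects them.

Compound 3, `Nc1ccccc1S(=O)(=O)N1CC(n2cc(F)c(=O)[nH]c2=O)OCc2ccccc21`, is not yet measured. It differs from compound 1 in one place: 2-aminophenyl in place of 4-aminophenyl on a sulfonyl sulfur. Among the compounds with values here, nothing measured so far speaks to this change, since no pair differing in one place has been tested.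

Within the data shown here, with no step of this kind to rest on, the expectation for compound 3 is set close to compound 1, and the step of a 1.0-fold lower number from compound 1 to compound 3 (0.01 log units; within the scatter) is expected to be small, in no firm direction. In this assay compound 3 is therefore estimated at 14000 nM, with a range from 4000 nM to 50000 nM.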

Compound 3, half-maximal inhibitory concentration: 54800 nM
Estimate against measurement, compound 3: 3.9-fold (0.59 log units) below, outside the stated range (above it).
By their numbers in this assay, from the lowest: compound 2; then compound 1; then compound 3.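

In this assay, the placement of the amino group on the phenyl carried by the sulfonyl sulfur matters: 2-aminophenyl in place of 4-aminophenyl gives a 3.8-fold higher number from compound 1 to compound 3 (0.58 log units; beyond the scatter) and thus a modest loss beyond the scatter. The leaving and entering groups have the same atoms and the same counts of donors and acceptors, so only the placement of the amine separates this pair, with 4-aminophenyl the stronger of the two on the shared core. Nothing at hand accounts for the shift.

This reading rests on a single pair, so it cannot yet be said how much of the activity depends on the amine itself. A bare phenyl, or a carboxylic acid in place of the amine, would test that on the same core.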